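The compounds below may be only part of what the source reports. "The series", "measured", "known", "first", "only" and "open" are said of these compounds alone.

Measured so far in a functional assay on HL-60 cells (Homo sapiens) for antiproliferative activity, read by MTT assay, with a stated time of 48 h; on this read-out lower numbers stand for stronger inhibition and higher numbers for weaker inhibition (both readings are limits):
- compound 1 (`Cn1c(N)c(-c2nc3ccccc3[nH]2)c2nc(C#N)c(C#N)nc21`) gives > 50000 nM as a limit
- compound 2 (`CCn1c(N)c(-c2nc3ccccc3[nH]2)c2nc(C#N)c(C#N)nc21`) gives > 50000 nM as a limit

Compound 2 stands only at a limit (> 50000 nM). The measured series sits wholly at one ceiling (the limit of > 50000 nM in this assay, at which 2 of the 2 values shown sit), so no number anchors the next step. The change to compound 3 (`CN(C)CCn1c(N)c(-c2nc3ccccc3[nH]2)c2nc(C#N)c(C#N)nc21`) is dimethylamino in place of hydrogen on a saturated chain carbon, two bonds along the chain from an aromatic nitrogen in the form of dimethylamino in place of hydrogen on a saturated chain carbon, two bonds along the chain from an aromatic nitrogen, or ethyl to 2-(dimethylamino)ethyl. Among the compounds with values here, the only measured step that bears on it (a step that the two limits leave unreadable from compound 1 to compound 2) has no readable size, and it sets neither size nor direction for this assay here. Only a modest shift from the ceiling toward stronger inhibition is expected, and a further limit is about as likely as a number. The estimated step (an at least 1.6-fold lower number from compound 2 to compound 3 (0.22 log units; that floor lies within the scatter)) rests on no measured size. For compound 3 the estimate is 30000 nM with an expected range from 6000 nM to 80000 nM as its ends.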

Compound 3, half-maximal inhibitory concentration: 2220 nM
For compound 3 the middle estimate is 14-fold (1.13 log units) above the measured one; measured number below the stated range.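

In this assay, the dimethylamino group on a saturated chain carbon, two bonds along the chain from an aromatic nitrogen, gives the series its first reading that is not a limit, with an at least 22-fold lower number from compound 2 to compound 3 (1.35 log units; beyond the scatter). Set against the methyl group on the same aromatic nitrogen, the change gives an at least 22-fold lower number from compound 1 to compound 3 (1.35 log units; beyond the scatter). The step between compound 1 and compound 2 cannot be read, and the two large steps give only minimum sizes, because both of those compounds stay at a limit: the limit of > 50000 nM in this assay, at which 2 of the 3 values shown sit.

From the compounds shown here alone, it remains open whether the gain depends on the dimethylamino group itself or would also appear with a primary amine, a morpholine or a pyrrolidine at the chain end. Also open, going by these compounds, is how a longer chain carrying the same dimethylamino group would read out.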